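The source may report more compounds than this note shows. Statements on the series, on what has been measured and on what is new or still open speak of the compounds shown alone.

Measured so far in a functional assay on MT4 cells (Homo sapiens) for cytotoxicity; on this read-out lower numbers stand for higher toxicity in this test and higher numbers for lower toxicity in this test:
- Compound 1 `Cc1ccc(C(=O)CSc2nc(O)c(C)c(Cc3cccc4ccccc34)n2)cc1` gives >= 251000 nM, which is a limit.
- Compound 2 `CC(=O)CSc1nc(O)c(C)c(Cc2cccc3ccccc23)n1` gives 85000 nM.

Compound 1 has no exact number: its result of >= 251000 nM is a limit of the assay. Compound 3 `CCc1c(O)nc(SCC(=O)c2ccc(C)cc2)nc1Cc1cccc2ccccc12` keeps the core of compound 1 and carries one change, (methyl in place of hydrogen on a saturated chain carbon bound to an aromatic carbon), which turns methyl into ethyl. Among the compounds with values here, the only measured step is an at least 2.9-fold lower number from compound 1 to compound 2 (0.47 log units; beyond the scatter). That step is methyl in place of 4-methylphenyl on a carbonyl carbon, so it lies at a different place and gives no direct size for this change. Within the data shown here, no measured step touches the changed place, so no step beyond the scatter is expected in this assay, and the expected result stays near the limit. The estimated step is an at least 1.1-fold lower number from compound 1 to compound 3 (0.05 log units; that floor lies within the scatter). For compound 3 the estimated value is 220000 nM, with an expected range from 80000 nM to 400000 nM.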

Compound 3, half-maximal cytotoxic concentration: 6000 nM
Beside the measured number, compound 3's estimate is 37-fold (1.56 log units) above it; the whole stated range lies above it.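

In this assay, the saturated chain carbon bound to an aromatic carbon turns out to be a sensitive place: adding one carbon, so that methyl becomes ethyl, gives an at least 41-fold lower number from compound 1 to compound 3 (1.62 log units; beyond the scatter). The earlier compounds shown here had differed only on the carbonyl carbon and said nothing about this place, whereas here a single added carbon is enough to bring a large rise in toxicity in this test. Compound 1 gives >= 251000 nM, which is a limit, so the size of this step is a floor and not an exact measure: the limit of >= 251000 nM in this assay, at which 1 of the 3 values shown sits.

The compounds shown leave open whether a longer chain, such as propyl, or a branched one, such as isopropyl, would lower the number further or reverse the change. They also leave open whether methyl to ethyl would have a similar effect in compound 2, which carries methyl on the carbonyl carbon.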